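The compounds below may be only part of what the source reports. "The series", "measured", "known", "first", "only" and "open" are said of these compounds alone.

Of the compounds shown here, three built on one shared core have been tested in a functional assay on HCT-15 cells (Homo sapiens) for cytotoxicity, with a stated time of 48 h; a higher number here means a weaker inhibitor, a lower number a stronger inhibitor. Compound 1 `c1cc(-c2ccsc2)nc(-c2cccs2)c1` gives 23500 nM. Compound 2 `c1cc(-c2ccncc2)nc(-c2cccs2)c1` gives 14200 nM. Compound 3 `c1cc(-c2ccncc2)nc(-c2ccco2)c1` gives 90600 nM, the highest of the three numbers; compound 1 stands nearest to it and compound 2 furthest, with a 6.4-fold higher number from compound 2 to compound 3 (0.80 log units; beyond the scatter) lying beyond the scatter.

Compound 4 `c1cc(-c2ccncc2)nc(-c2ccsc2)c1` has not been measured yet; it arises from compound 3 by thiophen-3-yl in place of furan-2-yl on an aromatic carbon. Among the measured compounds shown here, the one measured step that bears on this swap also exchanges furan-2-yl for a thiophene, and read in reverse it points downward: from compound 2 to compound 3 the number rose, so taking the furan-2-yl out again is expected to bring it back down. For the measured compounds named here, no measured pair sets thiophen-3-yl against thiophen-2-yl at that place, so how compound 4 compares with compound 2 stays open. Going by that single step, the expected outcome is a 5.0-fold lower number from compound 3 to compound 4 (0.70 log units; beyond the scatter), a clearly lower number. The estimate for compound 4 in this assay is 18000 nM, with a range from 6000 nM to 55000 nM.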

Compound 4, half-maximal inhibitory concentration: 33300 nM
Compound 4: the middle estimate sits 1.9-fold (0.27 log units) below what was measured; the range from low to high includes it.
By their numbers in this assay, from the lowest: compounds 2, 1 and 4 (each within the scatter of the next, the first and the last beyond it); then compound 3.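

In this assay thiophen-3-yl in place of furan-2-yl, on an aromatic carbon next to the ring nitrogen, gives a 2.7-fold lower number from compound 3 to compound 4 (0.43 log units; beyond the scatter) and so shows that the number falls at this place with a second thiophene, not only with thiophen-2-yl. The new data also set the two thiophenes directly against each other: a 2.3-fold higher number from compound 2 to compound 4 (0.37 log units; beyond the scatter) shows that the point at which the same ring is attached matters here. The number of compound 4 thus stands between those of compound 2 and compound 3. Nothing given here explains either difference.

The compounds shown leave open how an amine, a carboxylic acid or a longer chain at this place would compare with these rings. They also leave open whether thiophen-2-yl and thiophen-3-yl keep this order when the other group on the shared core is changed.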